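Taking one chain off compound 2

The compounds below may be only part of what the source reports. "The series", "measured", "known", "first", "only" and "open" are said of these compounds alone.

In a functional assay on OVCAR-3 cells (Homo sapiens) for antiproliferative activity, read by WST assay, with a stated time of 72 h, in the presence of a further agent that is not named here (a lower number here means a stronger inhibitor, a higher number a weaker inhibitor), compound 1 (`CCCCCCCC/C=C\c1c(C)nc(C)c(/C=C\CCCCCCCC)c1C`) has the entry "not determined" (no result reported), meaning no result was reported. For the measured compounds named here, compound 2 (`CCCCCCCC/C=C\c1c(C)c(/C=C\CCCCCCCC)c2[n+](c1C)CCC2`), at 860 nM, therefore gives the only number, with nothing to rank it against. Compound 3 (`CCCCCCCC/C=C\c1c(C)cc(C)[n+]2c1CCC2`) differs from compound 2 in one place: hydrogen in place of dec-1-en-1-yl on an aromatic carbon. Going by the values given here, no measured pair shows what this change does, so any forecast is uncertain. A moderate weakening is expected, with an estimated step of a 3.5-fold higher number from compound 2 to compound 3 (0.54 log units; beyond the scatter). Compound 3 is estimated at 3000 nM, within a range of 700 nM to 15000 nM.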

Compound 3, half-maximal inhibitory concentration: 900 nM
Compound 3: middle estimate off by 3.3-fold (0.52 log units), on the high side; measured number inside the range.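

In this assay, the step of a 1.0-fold higher number from compound 2 to compound 3 (0.02 log units; within the scatter) shows that this position, on an aromatic carbon two atoms from the ring nitrogen, can carry hydrogen instead of dec-1-en-1-yl with no difference beyond the scatter. The second chain is therefore not needed for the activity seen here, and a single dec-1-en-1-yl group on the shared core suffices. Nothing available explains this result. Going by these compounds, whether a longer chain or an amine at this position would give a similar number stays open, as does what the remaining dec-1-en-1-yl group contributes.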